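Swapping an amide for a tetrazole on the saturated ring

The source may hold more compounds than are shown below. What is called first, only, known or untested is meant among the compounds shown, and "the series" means these compounds.

Of the compounds shown here, two have been measured in an assay on isolated protein for inhibition of Long-chain-fatty-acid--CoA ligase 1 (Homo sapiens), read by mass spectrometry, with a stated time of 90 min, in the presence of a further agent that is not named here (on this read-out higher numbers stand for weaker inhibition and lower numbers for stronger inhibition), so far. Compound 1 `Cc1cccc(Cc2nc3cc(O[C@H]4CC[C@@H](C(=O)O)CC4)ccc3n2C)c1` carries a carboxylic acid on the saturated six-membered ring and gives 42 nM. Among the measured compounds shown here, compound 2 `Cc1cccc(Cc2nc3cc(O[C@H]4CC[C@@H](C(N)=O)CC4)ccc3n2C)c1` carries a primary amide in the same place and gives 950 nM, the higher of the two numbers; the only measured step, a 23-fold higher number from compound 1 to compound 2 (1.35 log units; beyond the scatter), shows how much ground was lost there. Compound 3 `Cc1cccc(Cc2nc3cc(O[C@H]4CC[C@@H](c5nnn[nH]5)CC4)ccc3n2C)c1` has not yet been tested; it differs from compound 2 by 1H-tetrazol-5-yl in place of carbamoyl on a saturated ring carbon. For the measured compounds named here, no measured step covers this change directly, so the expectation rests on the one step at that position. With compound 1 at 42 nM and compound 2 at 950 nM, compound 3 is expected to fall between them, nearer compound 1, in this assay. The estimated step is an 8.6-fold lower number from compound 2 to compound 3 (0.94 log units; beyond the scatter), a markedly lower number. Compound 3 is therefore estimated at 110 nM, within the range 30 nM to 450 nM.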

Compound 3, half-maximal inhibitory concentration: 34 nM
The estimate for compound 3 lay 3.2-fold (0.51 log units) above the measured number; the measured number falls inside the stated range.
By their numbers in this assay, from the lowest: compounds 3 and 1 (each within the scatter of the next); then compound 2.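

In this assay the tetrazole recovers all the ground lost with the amide: the swap gives a 28-fold lower number from compound 2 to compound 3 (1.45 log units; beyond the scatter) while a 1.2-fold lower number from compound 1 to compound 3 (0.09 log units; within the scatter) leaves the tetrazole and the carboxylic acid indistinguishable here. This ring carbon therefore accepts more than one group at the level of the acid, and a five-membered aromatic ring with four nitrogens can stand in for carboxy, whereas carbamoyl is the one of the three that stands apart. Nothing measured here explains why these two groups match and carbamoyl does not.

Going by these compounds, it stays open whether a sulfonic acid, a hydroxamic acid or a simple hydroxyl on this ring carbon would also match the carboxylic acid and the tetrazole. Also open is whether the match between these two groups would hold on a core other than the one shown.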